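This account rests on a few compounds, and the source may have more. Where it says the series, first, only, none or still open, it means among the compounds named here.

Of the compounds shown here, three that share one core have been measured in a functional assay on CHO cells with adenosine receptor A1 (Homo sapiens) as the target, read by cAMP accumulation and immunoassay, with a stated time of 6 min, tested at 0.1 uM; a higher number here means a weaker effect of the compound at the concentration tested, a lower number a stronger effect. Compound 1 `Nc1scc(CN2CCN(c3ccccc3C(F)(F)F)CC2)c1C(=O)c1ccc(Cl)cc1` gives -7.5%. Compound 2 `Nc1scc(CN2CCN(c3ccccc3F)CC2)c1C(=O)c1ccc(Cl)cc1` gives -1%. Compound 3 `Nc1scc(CN2CCN(c3c(F)cc(F)cc3F)CC2)c1C(=O)c1ccc(Cl)cc1` gives -3.9%, which is the second highest of the three numbers; its nearest neighbour is compound 2, with a number 2.9 percentage points lower from compound 2 to compound 3 (within the scatter), and the furthest is compound 1, with a number 3.6 percentage points higher from compound 1 to compound 3 (within the scatter). All three numbers therefore sit close together.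

Compound 4 `Nc1scc(CN2CCN(c3cccc(Cl)c3)CC2)c1C(=O)c1ccc(Cl)cc1` differs from compound 3 in one place: 3-chlorophenyl in place of 2,4,6-trifluorophenyl on an amine nitrogen in a ring. Going by the values given here, every measured step so far is of the same kind, a swap of the aromatic ring on the amine nitrogen in the ring, and none of them moved the read-out beyond the scatter: a number 6.5 percentage points higher from compound 1 to compound 2 (within the scatter), a number 3.6 percentage points higher from compound 1 to compound 3 (within the scatter) and a number 2.9 percentage points lower from compound 2 to compound 3 (within the scatter). On that basis no step beyond the scatter is expected in this assay for the change from compound 3 to compound 4, which is the expectation behind a number 0.1 percentage points lower from compound 3 to compound 4 (within the scatter). For compound 4 the estimated result is -4%, with a range from -14% to 6%.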

Compound 4, a percentage reported as activity, at one concentration (the size of the read-out at that concentration, not a potency): -20%
For compound 4 the middle estimate is 16 percentage points above the measured one; measured number outside the range, below it.
By their numbers in this assay, from the lowest: compound 4; then compounds 1, 3 and 2 (each within the scatter of the next).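

The aromatic ring on the amine nitrogen is therefore not a silent position in this assay: 3-chlorophenyl gives a number 16.1 percentage points lower from compound 3 to compound 4 (beyond the scatter), a number 19 percentage points lower from compound 2 to compound 4 (beyond the scatter) and a number 12.5 percentage points lower from compound 1 to compound 4 (beyond the scatter), so compound 4 shows the strongest effect of the four, although the swaps among the three earlier rings all stayed within the scatter. Two things change together in these steps, since 3-chlorophenyl brings chlorine in place of fluorine, and its name also carries a different ring number from 2-fluorophenyl, 2-(trifluoromethyl)phenyl and 2,4,6-trifluorophenyl. No measurement here explains why this ring gives the larger step.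

The compounds shown leave open whether the chlorine or its ring number matters more, a question that 2-chlorophenyl and 3-fluorophenyl would help to separate. From the compounds shown here alone, how 3-bromophenyl, 3-methoxyphenyl or plain phenyl would read also remains open.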